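The compounds below may be only part of what the source reports. "The series", "measured", "known", "first", "only" and "open" are said of these compounds alone.

In a functional assay on MDA-MB-231 cells (Homo sapiens) for antiproliferative activity, read by MTT assay, with a stated time of 72 h (on this read-out higher numbers stand for weaker inhibition and lower numbers for stronger inhibition), compound 1 (`CC(C)(C)NC(=O)CCc1cccc2c1B(O)OC2`) gives > 100000 nM, which is a limit of the assay and not a number. Compound 2 (`O=C(CCc1cccc2c1B(O)OC2)NC1CCCCC1`) gives > 100000 nM in this assay, again only a limit, so it has no exact position on the scale. For the measured compounds named here, the single measured step, a step that the two limits leave unreadable from compound 1 to compound 2, offers no size to carry forward. Going by the values given here, the series so far stands at the limit of > 100000 nM in this assay, at which 2 of the 2 values shown sit.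

The next structure is compound 3 (`O=C(CCc1cccc2c1B(O)OC2)Nc1ccc(F)cc1`). The change from compound 2 is 4-fluorophenyl in place of cyclohexyl on an amide-type nitrogen, which puts a six-membered aromatic ring of carbon only where a non-aromatic one stood, on the same amide-type nitrogen. Among the compounds with values here, no measured step bears on this exchange with a readable size, so the expectation rests on the two limits alone. In this assay, no step beyond the scatter is expected, and any shift would most plausibly be slight and towards stronger inhibition. The expected step is an at least 1.1-fold lower number from compound 2 to compound 3 (0.04 log units; that floor lies within the scatter). A limit, rather than a number, is the likelier report. If a number is obtained, compound 3 is expected at about 90000 nM, with an estimated range from 30000 nM to 200000 nM.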

Compound 3, half-maximal inhibitory concentration: 440 nM
The estimate for compound 3 lay 200-fold (2.31 log units) above the measured number; the measured number lies below the stated range.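

In this assay, the amide-type nitrogen proves to be a place where the choice of substituent can move compounds off the limit of the assay: an at least 220-fold lower number from compound 2 to compound 3 (2.35 log units; beyond the scatter) with 4-fluorophenyl in place of cyclohexyl, and an at least 220-fold lower number from compound 1 to compound 3 (2.35 log units; beyond the scatter) with 4-fluorophenyl in place of tert-butyl. The exchange of tert-butyl for cyclohexyl could not be read, so compound 1 and compound 2 alone gave no sign that this nitrogen responds to its substituent at all. Of the three compounds, compound 3 alone gives a number, while the other two remain at a limit of the assay and not at a number: the limit of > 100000 nM in this assay, at which 2 of the 3 values shown sit.

The compounds shown leave open whether this step belongs to the aromatic ring itself or to its fluorine, a question that a plain phenyl or a 4-chlorophenyl on the same nitrogen would address. They also leave open how far the number for compound 3 depends on the chain that carries the carbonyl, which a longer chain in its place would test.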